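Pyrimidine for Pyrazole: Outlook for Liver Microsome Stability

The source may report more compounds than this note shows. Statements on the series, on what has been measured and on what is new or still open speak of the compounds shown alone.

Compound 1, `Fc1ccc(N2CCN(CCCc3c[nH]c4ccc(F)cc34)CC2)c(-c2ccoc2)c1`: 0.172 h
Compound 2, `Fc1ccc2c(C3CCN(CCCc4c[nH]c5ccc(F)cc45)CC3)noc2c1`: 0.0767 h
Compound 3, `Fc1ccc(N2CCN(CCCc3c[nH]c4ccc(F)cc34)CC2)c(-c2cn[nH]c2)c1`: 0.12 h

All three were measured in an ADME assay on microsomes from liver (Rattus norvegicus) for metabolic stability, read by LC-MS, using NADPH, with a stated time of 90 min, tested at 1 uM; a lower number here means that the compound disappears faster, a higher number that the compound lasts longer. Compound 3 stands second highest of the three numbers; its nearest neighbour is compound 1 and its furthest is compound 2, and both lie within the scatter of compound 3. Compound 4, `Fc1ccc(N2CCN(CCCc3c[nH]c4ccc(F)cc34)CC2)c(-c2cncnc2)c1`, is not yet measured. It differs from compound 3 by pyrimidin-5-yl in place of 1H-pyrazol-4-yl on an aromatic carbon. Among the compounds with values here, only one measured step exchanges the group on that aromatic carbon: a 1.4-fold lower number from compound 1 to compound 3 (0.16 log units; within the scatter). That step lay within the scatter, and nothing measured speaks to pyrimidin-5-yl itself, so no step beyond the scatter is expected in this assay, in either direction. Compound 4 is therefore expected to give 0.12 h in this assay, between 0.06 h and 0.25 h. The expected step is no change at the digits printed from compound 3 to compound 4 (within the scatter).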

Compound 4, half-life: 0.11 h
Beside the measured number, compound 4's estimate is 1.1-fold (0.04 log units) above it; low and high end bracket the measured number.
By their numbers in this assay, from the lowest: compounds 2, 4, 3 and 1 (each within the scatter of the next, the first and the last beyond it).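

In this assay the change to pyrimidin-5-yl gives a 1.1-fold lower number from compound 3 to compound 4 (0.04 log units; within the scatter) and, set against furan-3-yl, a 1.6-fold lower number from compound 1 to compound 4 (0.19 log units; within the scatter), both within the scatter. This aromatic carbon, ortho to a large group, thus takes a six-membered aromatic ring with 0 hydrogen-bond donors with no step beyond the scatter, as it took the two five-membered rings. No measurement shown accounts for this. As far as these compounds go, whether an amine, a carboxylic acid or a plain phenyl ring on this carbon would move the half-life beyond the scatter remains open. Also open, from the compounds shown here alone, is whether any change at this position could do so without a change to the shared core.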